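From Chloro to Bromo on the Aromatic Ring

This account rests on a few compounds, and the source may have more. Where it says the series, first, only, none or still open, it means among the compounds named here.

In a functional assay on the whole organism for antagonist activity, with Mus musculus as the target (a higher number here means that more compound is needed for the effect, a lower number that less compound is needed), compound 1 `CCC(=O)N(c1cccc(OC)c1)C1CCCC1N(C)C` gives 4 mg/kg, while compound 2 `CCC(=O)N(c1cccc(Cl)c1)C1CCCC1N(C)C` gives 0.2 mg/kg. Compound 2 therefore holds the lower of the two numbers, so less of it is needed for the effect. Compound 3 `CCC(=O)N(c1cccc(Br)c1)C1CCCC1N(C)C`, not yet measured, keeps the shared core and differs from compound 2 as follows: bromo in place of chloro on an aromatic carbon. In short, it has bromo in place of chloro on an aromatic carbon.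

Within the data shown here, only one measured step bears on this change: a 20-fold lower number from compound 1 to compound 2 (1.30 log units; beyond the scatter). This large step came from chloro in place of methoxy on an aromatic carbon, and it shows that the group on this ring can matter in this assay. Among the measured compounds shown here, it is only a loose guide, however, since methoxy is a different kind of group, and no step from one halogen to another has been measured. A small change is therefore expected, with no clear direction and nothing beyond the scatter. The estimated step is a 1.3-fold higher number from compound 2 to compound 3 (0.10 log units; within the scatter). Compound 3 is expected to give 0.25 mg/kg, with an estimated range from 0.1 mg/kg to 0.6 mg/kg.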

Compound 3, dose for half-maximal effect: 0.1 mg/kg
For compound 3 the middle estimate is 2.5-fold (0.40 log units) above the measured one; the range from low to high includes it.
By their numbers in this assay, from the lowest: compounds 3 and 2 (each within the scatter of the next); then compound 1.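

In this assay, among these compounds, the first measured exchange of one halogen for another gives a 2.0-fold lower number from compound 2 to compound 3 (0.30 log units; within the scatter) and so stays within the scatter: on this aromatic carbon, bromo and chloro cannot be told apart by this read-out. Against the methoxy compound the picture is different, with a 40-fold lower number from compound 1 to compound 3 (1.60 log units; beyond the scatter) showing a large step beyond the scatter, so the wide gap first seen with chloro appears again with bromo and does not rest on chloro alone. Both halogens thus stand apart from methoxy in these three compounds, but nothing measured here accounts for that separation.

The compounds shown leave open how fluoro, iodo, methyl or trifluoromethyl would behave on this same aromatic carbon, and whether a hydroxyl group or an amine there would fall with compound 1 or with compound 2 and compound 3. They also leave open whether the separation between the halogens and methoxy would persist if the propanoyl chain or the dimethylamino group of the shared core were replaced.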